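The source may report more compounds than this note shows. Statements on the series, on what has been measured and on what is new or still open speak of the compounds shown alone.

Measured so far in a functional assay on A549 cells (Homo sapiens) for cytotoxicity, read by sulforhodamine B assay; a higher number here means a weaker inhibitor, a lower number a stronger inhibitor:
- compound 1 `Cc1cn(C2[Se][C@H](CO)[C@@H](O)[C@@H]2N=[N+]=[N-])c(=O)[nH]c1=O`: > 100000 nM
- compound 2 `[N-]=[N+]=N[C@@H]1C(n2cc(Cl)c(=O)[nH]c2=O)[Se][C@H](CO)[C@H]1O`: > 100000 nM

In this assay compound 1 gives > 100000 nM, and that figure is a limit of the assay rather than a measured number. Compound 2 carries chloro in place of methyl on an aromatic carbon of the shared core. In this assay compound 2 gives > 100000 nM, which is again only a limit. Between these two the step that the two limits leave unreadable from compound 1 to compound 2 cannot be sized, since both values sit at the limit of > 100000 nM in this assay, at which 2 of the 2 values shown sit, and nothing tells how far past it either compound lies.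

Compound 3 `[N-]=[N+]=N[C@@H]1C(n2cc(Br)c(=O)[nH]c2=O)[Se][C@H](CO)[C@H]1O` has not yet been measured. It differs from compound 1 as follows: bromo in place of methyl on an aromatic carbon. For the measured compounds named here, the only measured step that touches this kind of exchange is the unreadable one from compound 1 to compound 2, so no size or direction for the new step can be drawn from the data beyond the expectation that the value may once more rest at the limit. Compound 3 is therefore estimated at 150000 nM, with a range of 50000 nM to 500000 nM, amounting to an expected step that the limit leaves unreadable from compound 1 to compound 3.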

Compound 3, half-maximal inhibitory concentration: > 100000 nM
Compound 3 ended at the assay's limit (the forecaster's own chance of this, stated with the estimate: 80%); the middle value lies beyond the limit too.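

For the compounds shown here, no step among compound 1, compound 2 and compound 3 can be read, because none of the three has a measured number, only a limit: the limit of > 100000 nM in this assay, at which 3 of the 3 values shown sit. Still open, going by these compounds, is how far past that limit each compound lies, and so whether methyl, chloro or bromo on the aromatic carbon makes any difference in this assay.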